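Sulfonamide series: from 4-chlorophenyl to 4-bromophenyl

A few compounds are considered here, and "the series" means these few. Any claim that something is new, unique, unknown or untested is made for them only; others in the source may bear on it.

Compound 1 `Cc1ccc(NS(=O)(=O)c2ccc(N3CCNC3=O)cc2)cc1C`: 230 nM
Compound 2 `O=C1NCCN1c1ccc(S(=O)(=O)Nc2ccc(F)c(F)c2)cc1`: 350 nM
Compound 3 `O=C1NCCN1c1ccc(S(=O)(=O)Nc2ccc(Cl)cc2)cc1`: 220 nM

In a functional assay on HT-29 cells (Homo sapiens) for antiproliferative activity, read by sulforhodamine B assay, with a stated time of 48 h (on this read-out lower numbers stand for stronger inhibition and higher numbers for weaker inhibition), compound 3 gives 220 nM and is not separated from the other two measured compounds: the comparisons are a 1.0-fold lower number from compound 1 to compound 3 (0.02 log units; within the scatter) and a 1.6-fold lower number from compound 2 to compound 3 (0.20 log units; within the scatter).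

Next is compound 4 `O=C1NCCN1c1ccc(S(=O)(=O)Nc2ccc(Br)cc2)cc1`, with bromo in place of chloro on an aromatic carbon, para to a large group: bromo in place of chloro on an aromatic carbon.

Within the data shown here, no measured pair makes this exact exchange. The closest evidence comes from changes on the same sulfonamide nitrogen substituent, which also include a 1.5-fold higher number from compound 1 to compound 2 (0.18 log units; within the scatter). Each of these steps stays within the scatter, so no step beyond the scatter is expected in this assay, and no direction is favoured.

The expected result is no change at the digits printed from compound 3 to compound 4 (within the scatter).

For compound 4 the estimated value is 220 nM, with an expected range of 115 nM to 420 nM.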

Compound 4, half-maximal inhibitory concentration: 300 nM
Compound 4: the middle estimate sits 1.4-fold (0.13 log units) below what was measured; measured number inside the range.
By their numbers in this assay, from the lowest: compounds 3, 1, 4 and 2 (each within the scatter of the next).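

In this assay this position now has a direct reading of the halogen exchange: bromo in place of chloro, para to a large group, gives a 1.4-fold higher number from compound 3 to compound 4 (0.13 log units; within the scatter) and so does not separate the two compounds. The 4-bromophenyl group is likewise not separated from the other groups on the sulfonamide nitrogen, with a 1.2-fold lower number from compound 2 to compound 4 (0.07 log units; within the scatter) and a 1.3-fold higher number from compound 1 to compound 4 (0.12 log units; within the scatter), so all four compounds remain within the scatter of one another, with none going against this. No measurement shown bears on why the values fall as they do.

As far as these compounds go, it remains open whether this flat response extends beyond halogen and methyl substituents, for example to an amine, a carboxylic acid or a longer chain in the same place, para to a large group. From the compounds shown here alone, the effect of changes to the shared core also remains open.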